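A few compounds are considered here, and "the series" means these few. Any claim that something is new, unique, unknown or untested is made for them only; others in the source may bear on it.

Of the compounds shown here, three built on one shared core have been tested in an assay on FRT-Jurkat cells for inhibition of nuclear factor NF-kappa-B complex (Homo sapiens), read by flow cytometry, with a stated time of 24 h, tested at 10 uM; on this read-out higher numbers stand for more inhibition at the one concentration tested (going by the name of the read-out) and lower numbers for less inhibition. Compound 1 `O=C1CCC(N2C(=O)c3cccc(Nc4ccccn4)c3C2=O)C(=O)N1` gives 1% there. Compound 2 `CN(c1ccccc1)c1ccc2c(c1)C(=O)N(C1CCC(=O)NC1=O)C2=O` gives -2%, and compound 3 `CCCc1ccc(Nc2ccc3c(c2)C(=O)N(C2CCC(=O)NC2=O)C3=O)cc1` gives 10%. All three numbers lie within the usual scatter of one another, so compound 1 cannot be told apart from either of the others: its gap to compound 2 is the smaller one and its gap to compound 3 the larger, and neither counts as a real difference.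

Compound 4 `Cc1ccccc1Nc1cccc2c1C(=O)N(C1CCC(=O)NC1=O)C2=O` has not yet been measured. It differs from compound 1 in a single place: 2-methylphenyl in place of pyridin-2-yl on a nitrogen on an aromatic ring. Among the compounds with values here, no measured pair shows a change of this kind, so nothing in the data points to a step beyond the scatter in either direction. The step that the estimate means, a number 3 percentage points higher from compound 1 to compound 4 (within the scatter), is expected to stay within the scatter. Compound 4 is therefore estimated in this assay at 4%, with a range from -8% to 16%.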

Compound 4, a percentage reported as inhibition, at one concentration (the size of the read-out at that concentration, not a potency): 7%
For compound 4 the middle estimate is 3 percentage points below the measured one; the measured number falls inside the stated range.
By their numbers in this assay, from the lowest: compounds 2, 1, 4 and 3 (each within the scatter of the next, the first and the last beyond it).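

At this place, on a nitrogen on an aromatic ring, 2-methylphenyl can stand in for pyridin-2-yl without a difference that can be read in this assay, the swap giving a number 6 percentage points higher from compound 1 to compound 4 (within the scatter). Even with the hydrogen-bond acceptor of pyridin-2-yl gone and one more heavy atom present, the step stays inside the scatter. No measurement shown here offers an explanation for this step. Left open is what plain phenyl would do at this nitrogen, which would separate the methyl from the ring swap. Also open, going by these compounds, is whether a larger change, such as a carboxylic acid or an amine on this ring, would move the number beyond the scatter.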